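The source may hold more compounds than are shown below. What is called first, only, known or untested is meant among the compounds shown, and "the series" means these compounds.

Measured compounds in hand:
compound 1 `COc1ccc(-c2coc3cc(OCCCSC(=S)N4CCN(Cc5ccccc5)CC4)ccc3c2=O)cc1`; in a functional assay on MGC-803 cells (Homo sapiens) for inhibition, read by MTT assay, with a stated time of 48 h (on this read-out higher numbers stand for weaker inhibition and lower numbers for stronger inhibition), compound 1 gives 43800 nM
compound 2 `CCN1CCN(C(=S)SCCCOc2ccc3c(=O)c(-c4ccc(OC)cc4)coc3c2)CC1`; in this assay compound 2 gives 54000 nM
compound 3 `COc1ccc(-c2coc3cc(OCCSC(=S)N4CCN(C(=O)OC(C)(C)C)CC4)ccc3c2=O)cc1`; in this assay compound 3 gives 11600 nM

Compound 2 stands at the highest of the three numbers. Its nearest neighbour is compound 1: the step of a 1.2-fold higher number from compound 1 to compound 2 (0.09 log units; within the scatter) lies within the scatter, so the two cannot be ordered. Within the data shown here, compound 3 differs from compound 2 in more than one place, so no single step connects them; its value simply stands well below that of compound 2, beyond the scatter.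

Compound 4 `COc1ccc(-c2coc3cc(OCCCSC(=S)N4CCN(C)CC4)ccc3c2=O)cc1` is the next member. Against compound 2 the change is hydrogen in place of methyl on a saturated chain carbon bound to an amine nitrogen in a ring. Among the measured compounds shown here, the only measured step that bears on this place is the one from compound 1 to compound 2, which replaced phenyl by methyl there and gave a 1.2-fold higher number from compound 1 to compound 2 (0.09 log units; within the scatter), a change within the scatter. Removing a further carbon at the same place is a smaller alteration than that one, and nothing measured suggests a shift in either direction. The step of a 1.1-fold lower number from compound 2 to compound 4 (0.03 log units; within the scatter) is therefore expected to stay within the scatter. Compound 4 is estimated at 50000 nM in this assay, with a range from 22000 nM to 110000 nM.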

Compound 4, half-maximal inhibitory concentration: 21900 nM
Compound 4: middle estimate off by 2.3-fold (0.36 log units), on the high side; measured number outside the range, below it.
By their numbers in this assay, from the lowest: compounds 3, 4, 1 and 2 (each within the scatter of the next, the first and the last beyond it).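

In this assay the change from 4-ethylpiperazin-1-yl to 4-methylpiperazin-1-yl gives a 2.5-fold lower number from compound 2 to compound 4 (0.39 log units; beyond the scatter) as a modest step beyond the scatter, so this place does respond, which the earlier 1.2-fold higher number from compound 1 to compound 2 (0.09 log units; within the scatter) on its own did not show. The remaining comparison, a 2.0-fold lower number from compound 1 to compound 4 (0.30 log units; within the scatter) within the scatter, separates compound 4 from compound 2 only, leaves compound 1 unordered against both, and so gives no ranking of phenyl, methyl and hydrogen at this place. No measurement on hand accounts for the step from ethyl to methyl.

On these data alone, whether the step marks a real preference at this place rests on a single modest difference among three closely spaced compounds, so it remains open whether a propyl or hydroxyethyl group, or a bare hydrogen on the ring amine nitrogen, would extend it or leave the numbers within the scatter. Also open is how the length of the chain bearing the sulfur acts on its own, since no pair shown changes that chain alone.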